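The compounds below may be only part of what the source reports. "The series", "measured", "known", "first", "only" and "open" are said of these compounds alone.

Of the compounds shown here, two have numbers so far. Compound 1 `CC(C)n1cnc2c(Nc3ccccc3)nc(NCOCc3ccc(/C=C/C(=O)Nc4ccccc4N)cc3)nc21` gives 2.53% in a functional assay on HCT-116 cells (Homo sapiens) for antiproliferative activity, read by CCK-8 assay, with a stated time of 72 h, tested at 2 uM; a lower number here means a weaker effect, a higher number a stronger effect of the compound at the concentration tested. Compound 2 `Nc1ccccc1NC(=O)/C=C/c1ccc(COCNc2nc(Nc3cccc(Cl)c3)c3ncn(C4CCCC4)c3n2)cc1` gives 9.04% in this assay, the higher of the two numbers, though compound 1 sits within the scatter of it, so no order between them can be drawn. Compound 3 `CC(C)n1cnc2c(Nc3cccc(Cl)c3)nc(NCOCc3ccc(/C=C/C(=O)Nc4ccccc4N)cc3)nc21` is not yet measured; it differs from compound 2 in one place (isopropyl in place of cyclopentyl on an aromatic nitrogen). Both measured compounds are weak, and compound 1 already carries the isopropyl group, so the step from compound 2 to compound 3 in this assay is expected to stay within the scatter, a number 4 percentage points lower from compound 2 to compound 3 (within the scatter). Compound 3 is estimated at 5%, between -5% and 15%.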

Compound 3, a percentage reported as inhibition, at one concentration (the size of the read-out at that concentration, not a potency): 18.5%
Estimate against measurement, compound 3: 13.5 percentage points below; measured number above the stated range.
By their numbers in this assay, from the lowest: compounds 1, 2 and 3 (each within the scatter of the next, the first and the last beyond it).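

In this assay, isopropyl in place of cyclopentyl on the aromatic nitrogen gives a number 9.5 percentage points higher from compound 2 to compound 3 (within the scatter), so no effect of this change can be separated at this position. Chloro in place of hydrogen on an aromatic carbon gives a number 16 percentage points higher from compound 1 to compound 3 (beyond the scatter), the first step in the series to clear the scatter, though only modestly. No supporting measurement bears on this result.

The compounds shown leave open whether the chloro step holds with cyclopentyl on the nitrogen. They also leave open whether fluoro or methoxy in place of chloro, or a longer chain on the nitrogen, would move the number further.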